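Changing the Aromatic Group on the Shared Core

The source may hold more compounds than are shown below. What is called first, only, known or untested is meant among the compounds shown, and "the series" means these compounds.

Among the measured compounds shown here, compound 2 `CCCCCCCCc1ccc(OCC(=O)Cn2nnc(-c3cccc(C(=O)OC)c3)n2)cc1` gives 34 nM in an assay on microsomes from brain for inhibition of Fatty-acid amide hydrolase 1 (Rattus norvegicus), read by fluorescence and HPLC, with a stated time of 60 min (a higher number here means a weaker inhibitor, a lower number a stronger inhibitor), the higher of the two numbers measured so far, though compound 1 `CCCCCCCCc1ccc(OCC(=O)Cn2nnc(SC)n2)cc1` gives 31 nM and the step of a 1.1-fold higher number from compound 1 to compound 2 (0.04 log units; within the scatter) lies within the scatter. Compound 3 `CCCCCCCCc1ccc(OCC(=O)Cn2nnc(-c3ccc(S(=O)(=O)N(C)C)cc3)n2)cc1` differs from compound 2 by 4-(dimethylsulfamoyl)phenyl in place of 3-(methoxycarbonyl)phenyl on an aromatic carbon. For the measured compounds named here, only the step from compound 1 to compound 2 bears on this kind of change, and it stayed within the scatter, so no step beyond the scatter is expected now either. Compound 3 is therefore estimated at 35 nM, within 15 nM to 80 nM. The expected step is a 1.0-fold higher number from compound 2 to compound 3 (0.01 log units; within the scatter).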

Compound 3, half-maximal inhibitory concentration: 590 nM
Compound 3: the middle estimate sits 17-fold (1.23 log units) below what was measured; measured number outside the range, above it.
By their numbers in this assay, from the lowest: compounds 1 and 2 (each within the scatter of the next); then compound 3.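

In this assay this position proves sensitive to the group it carries: a 17-fold higher number from compound 2 to compound 3 (1.24 log units; beyond the scatter) comes with 4-(dimethylsulfamoyl)phenyl in place of 3-(methoxycarbonyl)phenyl, and a 19-fold higher number from compound 1 to compound 3 (1.28 log units; beyond the scatter) comes with the same group in place of methylsulfanyl. A six-membered aromatic ring here does not settle the number by itself, as compound 2 and compound 3 both carry one. Nothing measured here explains the jump. From the compounds shown here alone, compound 2 and compound 3 differ both in the group on the phenyl ring and in its place there, and which of these counts more stays open. Also open, going by these compounds, is how a carboxylic acid or an amine on that ring would read.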